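The source may report more compounds than this note shows. Statements on the series, on what has been measured and on what is new or still open speak of the compounds shown alone.

Working notes on the series.

Compound 1 `O=C(NCc1ccccc1)c1cnc(-c2ccccn2)nc1` gives 35.7 nM in an assay on isolated protein for inhibition of Hematopoietic prostaglandin D synthase (Homo sapiens), read by ELISA; a higher number here means a weaker inhibitor, a lower number a stronger inhibitor. Compound 2 `O=C(NCc1ccccc1)c1cnc(-c2ccccc2)nc1` carries phenyl in place of pyridin-2-yl on an aromatic carbon and gives 23.9 nM in this assay; the step is a 1.5-fold lower number from compound 1 to compound 2 (0.17 log units; within the scatter), so the two amides sit together.

Compound 3 `c1ccc(-c2ncc(-c3cnc(-c4ccccn4)nc3)[nH]2)cc1` is built on a different core; how its core differs from the core of compound 1 is not broken down here. In this assay compound 3 gives 5060 nM, the highest of the three numbers, beyond the scatter from both compound 1 and compound 2.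

Compound 4 `c1ccc(-c2ncc(-c3cnc(-c4ccccc4)[nH]3)cn2)cc1` is not yet measured in this assay. It differs from compound 3 by phenyl in place of pyridin-2-yl on an aromatic carbon, the same change as that from compound 1 to compound 2, at a place described in the same words. On the amide core this change moved the number only within the scatter, as a 1.5-fold lower number from compound 1 to compound 2 (0.17 log units; within the scatter) shows, and that single pair is all that supports a transfer to the other core.

Among the compounds with values here, the expected step from compound 3 to compound 4 in this assay is therefore a 1.3-fold lower number from compound 3 to compound 4 (0.12 log units; within the scatter), close to the earlier one, with wide bounds because only one example exists. Compound 4 is estimated at 3800 nM in this assay, between 1400 nM and 12000 nM.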

Compound 4, half-maximal inhibitory concentration: 59 nM
The estimate for compound 4 lay 64-fold (1.81 log units) above the measured number; the whole stated range lies above it.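

In this assay, phenyl in place of pyridin-2-yl on the core of compound 3 gives an 86-fold lower number from compound 3 to compound 4 (1.93 log units; beyond the scatter). The size of this step therefore does not carry over from the amide core to the core of compound 3: the same change on two cores in this assay, a 1.5-fold lower number (0.17 log units; within the scatter) from compound 1 to compound 2 and an 86-fold lower number (1.93 log units; beyond the scatter) from compound 3 to compound 4, 57-fold (1.76 log units) apart, beyond the scatter of two such steps This shows that, for these two pairs, the effect of the change depends on the core that carries it, but with one pair per core it does not show why the steps differ or give a rule for any further core.

The compounds shown leave open whether the large step on the core of compound 3 is specific to phenyl or would also appear with another group at the same place, such as an amine, a methoxy group or a pyridin-3-yl ring. From the compounds shown here alone, it also remains open whether a carboxylic acid or a longer chain on the phenyl of compound 4 would keep the number at the level of compound 4 or return it toward that of compound 3.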